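Dimethyl substitution on the sulfonamide aryl ring

The source may report more compounds than this note shows. Statements on the series, on what has been measured and on what is new or still open speak of the compounds shown alone.

Three sulfonamides built on a shared core have been measured in a functional assay on M21 cells (Homo sapiens) for antiproliferative activity, read by sulforhodamine B assay, with a stated time of 48 h; a higher number here means a weaker inhibitor, a lower number a stronger inhibitor. Compound 1 `Cc1ccccc1NS(=O)(=O)c1ccc(N2CCNC2=O)cc1` gives 150 nM, compound 2 `O=C1NCCN1c1ccc(S(=O)(=O)Nc2ccc(Br)cc2)cc1` gives 130 nM, and compound 3 `O=C1NCCN1c1ccc(S(=O)(=O)Nc2ccccc2)cc1` gives 200 nM. Compound 3 has the highest of the three numbers, but the steps to the others are small: a 1.5-fold higher number from compound 2 to compound 3 (0.19 log units; within the scatter) and a 1.3-fold higher number from compound 1 to compound 3 (0.12 log units; within the scatter), both within the scatter, so no order among the three can be claimed.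

The unmeasured compound 4 `Cc1ccc(C)c(NS(=O)(=O)c2ccc(N3CCNC3=O)cc2)c1` differs from compound 3 in one place: 2,5-dimethylphenyl in place of phenyl on a sulfonamide nitrogen. Going by the values given here, the step that bears on this change is the one from compound 1 to compound 3, where a methyl on an aromatic carbon is replaced by hydrogen, and a 1.3-fold higher number from compound 1 to compound 3 (0.12 log units; within the scatter) stayed within the scatter. The step from compound 2 to compound 3, swapping an aromatic bromo for hydrogen, likewise gave a 1.5-fold higher number from compound 2 to compound 3 (0.19 log units; within the scatter). Among the compounds with values here, nothing among the measured compounds shows that a second methyl on this ring moves the number beyond the scatter.

Compound 4 is therefore expected to show a 1.3-fold lower number from compound 3 to compound 4 (0.12 log units; within the scatter), a step that would itself lie within the scatter. The estimate for compound 4 in this assay is 150 nM, with a range from 70 nM to 320 nM.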

Compound 4, half-maximal inhibitory concentration: 27 nM
Compound 4: middle estimate off by 5.6-fold (0.74 log units), on the high side; measured number below the stated range.
By their numbers in this assay, from the lowest: compound 4; then compounds 2, 1 and 3 (each within the scatter of the next).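

In this assay, going by these compounds alone, 2,5-dimethylphenyl on the sulfonamide nitrogen is the first change at this position to move the number beyond the scatter, with a 7.4-fold lower number from compound 3 to compound 4 (0.87 log units; beyond the scatter) set against steps among compounds 1, 2 and 3 that all stayed within it. The second methyl gives a 5.6-fold lower number from compound 1 to compound 4 (0.74 log units; beyond the scatter) in a single step, whereas taking away the first methyl gave only a 1.3-fold higher number from compound 1 to compound 3 (0.12 log units; within the scatter), so among these compounds the two methyls do not act as two equal increments. Compound 4 also stands apart from the 4-bromophenyl analogue, with a 4.8-fold lower number from compound 2 to compound 4 (0.68 log units; beyond the scatter), which places it lowest of the four, with all of its steps beyond the scatter.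

Nothing given here accounts for the size of this drop. From the compounds shown here alone, it remains open whether the second methyl would have the same effect on a ring without the first, and whether ethyl, methoxy or chloro could stand in place of the two methyls and keep the number this low.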